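Adding an Acetyl Group to a Dithiolane-Coumarin Conjugate

This account rests on a few compounds, and the source may have more. Where it says the series, first, only, none or still open, it means among the compounds named here.

Of the compounds shown here, three sharing one core have been tested in a functional assay on PC-12 cells (Rattus norvegicus) for cytotoxicity, read by MTT assay, with stated times of 3 h and 2 h, tested at 0.1 uM; a higher number here means a stronger effect of the compound at the concentration tested, a lower number a weaker effect. Compound 2, `O=C(CCCCC1CCSS1)NCc1cn(CCCCCOc2ccc3ccc(=O)oc3c2)nn1`, gives 46.3%, the highest of the three numbers. Compound 3, `Cc1cc(=O)oc2cc(OCCCCCn3cc(CNC(=O)CCCCC4CCSS4)nn3)ccc12`, differs from it only by methyl in place of hydrogen on an aromatic carbon and gives 45.6%, so that a number 0.7 percentage points lower from compound 2 to compound 3 (within the scatter). Compound 1, `COc1ccc(-c2cc3ccc(OCCCCn4cc(CNC(=O)CCCCC5CCSS5)nn4)cc3oc2=O)cc1`, gives 32.1% and differs from compound 2 in more than one place, so no single step can be read from the pair.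

Compound 4, `CC(=O)c1cc2ccc(OCCCCCn3cc(CNC(=O)CCCCC4CCSS4)nn3)cc2oc1=O`, is not yet measured. It differs from compound 2 as follows: acetyl in place of hydrogen on an aromatic carbon. Within the data shown here, the only measured step that bears on this change is the one from compound 2 to compound 3, where a small group entered at an aromatic carbon of the same ring without moving the number beyond the scatter. By analogy, the acetyl group is expected to leave the number roughly where compound 2 stands, so that the step of a number 3.3 percentage points lower from compound 2 to compound 4 (within the scatter) is expected to be small. Compound 4 is therefore estimated at 43%, within a range from 30% to 56%.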

Compound 4, a percentage reported as activity, at one concentration (the size of the read-out at that concentration, not a potency): 28.9%
Estimate against measurement, compound 4: 14.1 percentage points above; measured number outside the range, below it.
By their numbers in this assay, from the lowest: compounds 4 and 1 (each within the scatter of the next); then compounds 3 and 2 (each within the scatter of the next).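

On this aromatic carbon, two atoms from the ring oxygen, putting acetyl in place of hydrogen does move the result in this assay, giving a number 17.4 percentage points lower from compound 2 to compound 4 (beyond the scatter). The earlier methyl change gave a number 0.7 percentage points lower from compound 2 to compound 3 (within the scatter), so that step cannot stand for every small group placed on this ring, and a substituent of 3 heavy atoms with one carbonyl is enough here to take the number beyond the scatter. No measurement at hand explains why the acetyl change has this effect.

As far as these compounds go, it remains open whether an ethyl group or a carboxylic acid on the same carbon would lower the number as acetyl does. From the compounds shown here alone, it is also open whether a longer acyl chain there would lower it further or leave it where compound 4 stands.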